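This account rests on a few compounds, and the source may have more. Where it says the series, first, only, none or still open, it means among the compounds named here.

Measured in an ADME assay on microsomes from liver (Mus musculus, strain CD-1) for metabolic stability, read by LC-MS, with a stated time of 60 min, tested at 20 uM; a lower number here means that the compound disappears faster, a higher number that the compound lasts longer:

Compound 1 `O=c1c2cn(C3COC3)nc2nc(SCc2cccc(F)c2)n1-c1ccccc1`: 0.383 h
Compound 2 `COc1cccc(C(C)Sc2nc3c(cnn3C)c(=O)n2-c2ccccc2)c1`: 0.1 h

Compound 1 holds the higher of these two numbers, and the gap down to compound 2 lies beyond the scatter. Among the measured compounds shown here, that leaves compound 1 with no measured compound above it in this assay.

Compound 3 `CC(Sc1nc2nn(C3COC3)cc2c(=O)n1-c1ccccc1)c1ccccn1` departs from compound 1 in one place, with 1-(pyridin-2-yl)ethyl in place of 3-fluorobenzyl on a sulfur. For the measured compounds named here, no measured step isolates this change, so any expectation is loose. Going by the values given here, the only other number available is that of compound 2 at 0.1 h, and this points the expectation downward rather than upward. The expected change is a 1.7-fold lower number from compound 1 to compound 3 (0.24 log units; within the scatter), a modest fall that may stay within the scatter. For compound 3 the estimate is 0.22 h, with an expected range from 0.08 h to 0.6 h.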

Compound 3, half-life: > 1 h
Compound 3 was reported as a limit; the forecaster's own chance of this, stated with the estimate: 5%; middle value at least 4.5-fold (0.65 log units) from the limit.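

Among the compounds shown here, on the sulfur of the core of compound 1, the exchange of 3-fluorobenzyl for 1-(pyridin-2-yl)ethyl gives the first directly readable step in this set, and in this assay it brings an at least 2.6-fold higher number from compound 1 to compound 3 (0.41 log units; beyond the scatter). With the rest of the structure unchanged, the group on this sulfur alone moves the half-life beyond the scatter. The value of compound 3, > 1 h, is a limit and not a number, and the step built on it carries that limit: the limit of > 1 h in this assay, at which 1 of the 3 values shown sits.

The step exchanges the whole group at once, so it cannot separate the ring nitrogen, the ethyl link and the loss of fluorine from one another. Nor do the compounds shown tell how an unsubstituted benzyl or a pyridin-2-ylmethyl group on that sulfur would fare.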